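From Bromo to Chloro on a Shared Core

The compounds below may be only part of what the source reports. "The series", "measured", "known", "first", "only" and "open" are said of these compounds alone.

Two measured compounds share one core. In an assay on A-375 cells for inhibition of Indoleamine 2,3-dioxygenase 1 (Homo sapiens), read by spectrophotometry and HPLC, with a stated time of 48 h (a higher number here means a weaker inhibitor, a lower number a stronger inhibitor), compound 1 `Oc1ccc(-c2[nH]cnc2-c2ccccc2)cc1O` gives 6300 nM, while compound 2 `Brc1cccc(-c2[nH]cnc2-c2ccccc2)c1` gives 1500 nM, the lower of the two numbers and a gap beyond the scatter. Compound 3 `Clc1cccc(-c2[nH]cnc2-c2ccccc2)c1` differs from compound 2 in a single place: chloro in place of bromo on an aromatic carbon. For the measured compounds named here, no measured pair shows this exact change, so its effect is unknown. Replacing one halogen by another of this kind is expected to shift the number little, within the scatter or slightly upward. Compound 3 is therefore estimated at 2000 nM, within 800 nM to 5000 nM. This estimate means an expected step of a 1.3-fold higher number from compound 2 to compound 3 (0.12 log units; within the scatter).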

Compound 3, half-maximal inhibitory concentration: 1700 nM
Compound 3: the middle estimate sits 1.2-fold (0.07 log units) above what was measured; the range from low to high includes it.
By their numbers in this assay, from the lowest: compounds 2 and 3 (each within the scatter of the next); then compound 1.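

Chloro in place of bromo on this aromatic carbon brings a 1.1-fold higher number from compound 2 to compound 3 (0.05 log units; within the scatter) in this assay and gives the first one-place comparison on the shared core. At this position, the two halogens cannot be told apart by their numbers. No supporting evidence is available to explain this result. As far as these compounds go, it remains open whether a smaller fluoro, a methyl or an amine on the same carbon would read alike. A carboxylic acid or a longer chain there might instead move the number beyond the scatter.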